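The source may hold more compounds than are shown below. What is called first, only, known or untested is meant among the compounds shown, and "the series" means these compounds.

Compound 1 `CC1(CO)OCC(n2ccc(N)nc2=O)O1`: 100000 nM
Compound 2 `C[C@]1(CO)OC[C@@H](n2cc(F)c(N)nc2=O)O1`: > 100000 nM
Compound 3 `CC1(CO)OCC(n2cc(F)c(N)nc2=O)O1`: > 100000 nM

All three were tested in a functional assay on B16-F10 cells (Mus musculus) for inhibition; a lower number here means a stronger inhibitor, a higher number a weaker inhibitor. In this assay compound 1 gives 100000 nM. For compound 2 the assay reports only a limit, > 100000 nM. For compound 3 as well the assay reports only a limit, > 100000 nM. Compound 3 therefore stands at the edge of what this assay resolves, and one further value in the set is also a limit. The step of a number no lower from compound 1 to compound 3 (the limit leaves the size open) cannot be sized because of the limit of > 100000 nM in this assay, at which 2 of the 3 values shown sit. The step that the two limits leave unreadable from compound 2 to compound 3 is likewise unreadable because of the limit of > 100000 nM in this assay, at which 2 of the 3 values shown sit, together with the fact that one of compounds 2 and 3 is drawn with a defined configuration and the other without, at the place where they differ.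

Compound 4 `C[C@]1(CO)OCC(n2cc(F)c(N)nc2=O)O1` differs from compound 3 as follows: the two compounds have the same atoms and bonds; at least one stereo element is drawn with a configuration in one of them and without one in the other: 1 of 2 stereo elements differ; a stereocentre at a saturated ring carbon is drawn without a configuration in compound 3 and S in compound 4. Within the data shown here, the only measured step of the same kind, a step that the two limits leave unreadable from compound 2 to compound 3, shows nothing beyond the limit. The expectation is therefore that no readable step appears in this assay, the estimated step being a number no higher from compound 3 to compound 4 (the limit leaves the size open). Compound 4 is expected to be reported again as a limit, estimated at 100000 nM with a range of 50000 nM to 300000 nM.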

Compound 4, half-maximal inhibitory concentration: > 100000 nM
Compound 4 ended at the assay's limit; the forecaster's own chance of this, stated with the estimate: 85%; the middle value sits exactly at the limit.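

In this assay compound 4 gives only the limit > 100000 nM and, as compounds 2 and 3 also stand at limits, no step among these three compounds can be read. The compounds shown leave open how strongly compounds 2, 3 and 4 inhibit and whether in this assay the drawn configuration at the saturated ring carbons makes any difference.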